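Removing the Trifluoromethyl Group from Compound 2

The source may report more compounds than this note shows. Statements on the series, on what has been measured and on what is new or still open speak of the compounds shown alone.

Of the compounds shown here, two built on the same core have so far been tested in a functional assay on BGC-823 cells (Homo sapiens) for antiproliferative activity, read by sulforhodamine B assay, tested at 100 ug/mL; on this read-out lower numbers stand for less inhibition and higher numbers for more inhibition at the one concentration tested (going by the name of the read-out). Compound 1 `Cc1ccc(NS(=O)(=O)C2CCCCC2=O)c(C)c1` gives 15.6% in this assay. For the measured compounds named here, compound 2 `O=C1CCCCC1S(=O)(=O)Nc1ccc(Cl)cc1C(F)(F)F` gives 36.4% in this assay, the higher of the two numbers, and its gap to compound 1, the only other compound measured, lies beyond the usual scatter of repeated measurements. Compound 3 `O=C1CCCCC1S(=O)(=O)Nc1ccc(Cl)cc1` has not been measured yet. It differs from compound 2 in a single place: hydrogen in place of trifluoromethyl on an aromatic carbon. Going by the values given here, no two measured compounds differ from each other in exactly one place, so there is no step of this kind to lean on, and compound 1 differs from compound 2 in more than one place, which makes it an unclean comparison. With the trifluoromethyl group gone, the step from compound 2 to compound 3 is expected to be a number 11.4 percentage points lower from compound 2 to compound 3 (beyond the scatter), a modest drop in inhibition, though a change within the scatter would not surprise. Compound 3 is therefore estimated to give about 25% in this assay, within a range from 8% to 42%.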

Compound 3, a percentage reported as inhibition, at one concentration (the size of the read-out at that concentration, not a potency): 16%
Compound 3: middle estimate off by 9 percentage points, on the high side, within the range that was stated.
By their numbers in this assay, from the lowest: compounds 1 and 3 (each within the scatter of the next); then compound 2.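

With this pair, two compounds finally differ in one place only, so the trifluoromethyl group can be judged on its own. In this assay, putting hydrogen in its place on this aromatic carbon, ortho to a large group and meta to a chloro group, gives a number 20.4 percentage points lower from compound 2 to compound 3 (beyond the scatter) with the rest of the structure unchanged, which shows that the group on this carbon matters for the inhibition seen at the one concentration tested, and that trifluoromethyl here gives more of it than hydrogen does. No measurement at hand offers a reason for this step.

Still open, from the compounds shown here alone, is whether a nitrile, a methoxy group or an amine on this same carbon would give a number closer to that of compound 2 or to that of compound 3. Also open, going by these compounds, is whether the step would keep its size with something other than the chloro group on the ring, and, since each compound has a reading at a single concentration only, whether the same step would appear in a measure of potency.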